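From ethyl to carboxymethyl on the lead compound

This account rests on a few compounds, and the source may have more. Where it says the series, first, only, none or still open, it means among the compounds named here.

In a functional assay on HT-29 cells (Homo sapiens) for inhibition, with a stated time of 72 h (on this read-out lower numbers stand for stronger inhibition and higher numbers for weaker inhibition), compound 1 (`COc1cc(C(=O)n2ccc3ccccc32)cc(OC)c1OC`) gives 9600 nM and compound 2 (`CCn1ccc2cc(C(=O)c3cc(OC)c(OC)c(OC)c3)ccc21`) gives 32 nM as the lower of the two numbers, a gap well beyond the scatter. Compound 3 (`COc1cc(C(=O)c2ccc3c(ccn3CC(=O)O)c2)cc(OC)c1OC`) is still unmeasured and carries carboxy in place of methyl on a saturated chain carbon bound to an aromatic nitrogen. Among the compounds with values here, no measured pair shows this change, so the expectation rests on the structural change alone. In this assay the expected step is a 63-fold higher number from compound 2 to compound 3 (1.80 log units; beyond the scatter) toward weaker inhibition, beyond the scatter. For compound 3 the estimated value is 2000 nM with an expected range from 250 nM to 15000 nM around it.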

Compound 3, half-maximal inhibitory concentration: 460 nM
The estimate for compound 3 lay 4.3-fold (0.64 log units) above the measured number; the measured number falls inside the stated range.
By their numbers in this assay, from the lowest: compound 2; then compound 3; then compound 1.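

In this assay the change from ethyl to carboxymethyl gives a 14-fold higher number from compound 2 to compound 3 (1.16 log units; beyond the scatter) toward weaker inhibition, so this position does not tolerate the change without a large loss. Even so, compound 3 gives 460 nM and keeps measurable inhibition with carboxy on a saturated chain carbon bound to an aromatic nitrogen. Nothing at hand explains the size of this step.

The compounds shown leave open how a methyl ester, a primary amide or an amine would fare at this place. They also leave open whether a longer chain ending in a carboxylic acid would differ from carboxymethyl.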